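The compounds below may be only part of what the source reports. "The series", "measured", "known", "first", "only" and "open" are said of these compounds alone.

Measured so far in a functional assay on A-375 cells (Homo sapiens) for cytotoxicity, read by MTT assay; a lower number here means a stronger inhibitor, a higher number a weaker inhibitor:
- compound 1 `COc1ccc(/C=C/C(=O)c2ccc(OC)c3c2OC(C)(C)C=C3)cc1OC(=O)C(C)C`: 310 nM
- compound 2 `COc1ccc(/C=C/C(=O)c2ccc(OC)c3c2OC(C)(C)C=C3)cc1OC(=O)CCl`: 450 nM

Among the compounds with values here, compound 2 cannot be separated from compound 1, the only other measured compound, since their two values lie within the scatter of each other. Compound 3 `COc1cccc(C(=O)Oc2cc(/C=C/C(=O)c3ccc(OC)c4c3OC(C)(C)C=C4)ccc2OC)c1` has not yet been measured. It keeps the shared core and differs from compound 2 at one place: 3-methoxyphenyl in place of chloromethyl on a carbonyl carbon. In words, 3-methoxyphenyl stands in place of chloromethyl on a carbonyl carbon.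

Within the data shown here, one measured step bears on this change, as it falls at the same place: a 1.5-fold higher number from compound 1 to compound 2 (0.16 log units; within the scatter). That exchange of isopropyl for chloromethyl stayed within the scatter, but it involved no ring, so the data say nothing direct about the entering 3-methoxyphenyl. No direction can be favoured on this evidence, and no shift beyond the scatter is expected in this assay. The estimated change is a 1.1-fold lower number from compound 2 to compound 3 (0.05 log units; within the scatter). Among the measured compounds shown here, the range is kept wide, as only two compounds have been measured at this place. For compound 3 the expected value is 400 nM, within an estimated range of 140 nM to 1200 nM.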

Compound 3, half-maximal inhibitory concentration: 800 nM
Beside the measured number, compound 3's estimate is 2.0-fold (0.30 log units) below it; the measured number falls inside the stated range.
By their numbers in this assay, from the lowest: compounds 1, 2 and 3 (each within the scatter of the next, the first and the last beyond it).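

In this assay, within the data shown here, the position on the carbonyl carbon now carries a ring for the first time, and the exchange of chloromethyl for 3-methoxyphenyl gives a 1.8-fold higher number from compound 2 to compound 3 (0.25 log units; within the scatter), so this larger group cannot be separated from chloromethyl. Set against isopropyl, however, the same group gives a 2.6-fold higher number from compound 1 to compound 3 (0.41 log units; beyond the scatter), a modest step and the first at this position to be separated from the scatter, showing that the choice of group here can shift the number, though only slightly among these three compounds. Nothing measured alongside these numbers speaks to the cause of either step.

The compounds shown leave open whether the step from isopropyl belongs to the aromatic ring itself or to its methoxy group, a question that a plain phenyl group on the same carbonyl carbon would address. Also open, on these data alone, is how an aminomethyl group or a longer alkyl chain at this place would read in this assay.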